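Trimming the Ester Tail: Phenoxymethyl Becomes Phenyl

This account rests on a few compounds, and the source may have more. Where it says the series, first, only, none or still open, it means among the compounds named here.

Of the compounds shown here, three have been measured in an assay on nucleic acid for inhibition of Nucleic Acid, read by fluorescence, tested at 100 uM; on this read-out lower numbers stand for less inhibition and higher numbers for more inhibition at the one concentration tested (going by the name of the read-out). Compound 1 `O=C(COc1ccccc1)OC1CCCCC1n1cc(CN2CCC(c3ccccc3)CC2)nn1` gives 42%, the highest of the three numbers. Compound 2 `CCOC(=O)C1CCCN(Cc2cn(C3CCCCC3OC(=O)COc3ccccc3)nn2)C1` gives 21%, a number below that of compound 1 by a margin beyond the usual scatter. Compound 3 `CC(C)CCN(C)Cc1cn(CC(O)COC(=O)c2ccccc2)nn1` gives 0%, further below compound 1 still, also beyond the scatter. No two of these compounds differ in only one place, so none of the gaps between them can be tied to a single change in structure; the three show only that compound 1 stands at the top of this small set.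

Compound 4 `O=C(OC1CCCCC1n1cc(CN2CCC(c3ccccc3)CC2)nn1)c1ccccc1` has not yet been measured. It departs from compound 1 in one place, the carbonyl carbon of the ester: phenyl in place of phenoxymethyl on a carbonyl carbon. Everything else in the molecule, including the shared core and the triazole-linked piperidine arm, is unchanged.

Among the measured compounds shown here, with no measured step of this kind available, the expectation for compound 4 rests on the value of compound 1 in this assay alone, and the step of a number 4 percentage points lower from compound 1 to compound 4 (within the scatter) is expected to be small, not clearly beyond the scatter in either direction. Compound 4 is therefore estimated at 38%, with a range from 20% to 55%.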

Compound 4, a percentage reported as inhibition, at one concentration (the size of the read-out at that concentration, not a potency): 16%
Compound 4: middle estimate off by 22 percentage points, on the high side; the whole stated range lies above it.
By their numbers in this assay, from the lowest: compound 3; then compounds 4 and 2 (each within the scatter of the next); then compound 1.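

In this assay, among the compounds shown here, the move from phenoxymethyl to phenyl on a carbonyl carbon gives a number 26 percentage points lower from compound 1 to compound 4 (beyond the scatter) and is the first gap in this set that can be tied to a single place in the structure. With the shared core and the triazole-linked piperidine arm unchanged, it shows that this end of the ester is not a neutral spot: the read-out responds when phenoxymethyl, with 8 heavy atoms including 1 oxygen, gives way to phenyl, with 6 carbons, and the aromatic ring itself remains in both. No measurement here bears on why the number falls, so the step records an outcome and offers no explanation.

Phenoxymethyl differs from phenyl by both a carbon and an oxygen, so this single step cannot say which of the two matters, or whether both do; benzyl, which keeps the carbon and drops the oxygen, would pull the two apart. Also open, on these data alone, is whether a longer chain such as phenoxyethyl on the same carbonyl carbon would carry the number in either direction, and whether the same swap behaves alike with a different arm on the triazole.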